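Swapping the Ring-Bearing Ester for a Sulfonamide Chain

The compounds below may be only part of what the source reports. "The series", "measured", "known", "first", "only" and "open" are said of these compounds alone.

Among three compounds sharing one core, compound 3 `CC1(C)CC(OC(=O)CN2CN(c3ccccc3)C3(CCN(C(=O)c4ccc(C5CCCCC5)cc4)CC3)C2=O)CC(C)(C)N1` gives the lowest number in an assay on HEK293 cells for displacement of a labelled ligand from NPC1-like intracellular cholesterol transporter 1 (Homo sapiens) (on this read-out lower numbers stand for stronger inhibition and higher numbers for weaker inhibition), at 600 nM. Compound 1 `CC(C)(C)OC(=O)NCCNC(=O)CN1CN(c2ccccc2)C2(CCN(C(=O)c3ccc(C4CCCCC4)cc3)CC2)C1=O` gives 5500 nM and compound 2 `COC(=O)CCCNC(=O)CN1CN(c2ccccc2)C2(CCN(C(=O)c3ccc(C4CCCCC4)cc3)CC2)C1=O` gives 2500 nM in this assay. Compound 4 `CS(=O)(=O)NCCNC(=O)CN1CN(c2ccccc2)C2(CCN(C(=O)c3ccc(C4CCCCC4)cc3)CC2)C1=O` differs from compound 3 by (2-(methanesulfonamido)ethyl)amino in place of (2,2,6,6-tetramethylpiperidin-4-yl)oxy on a carbonyl carbon. Among the measured compounds shown here, two measured steps bear on this: both a 9.2-fold lower number from compound 1 to compound 3 (0.96 log units; beyond the scatter) and a 4.2-fold lower number from compound 2 to compound 3 (0.62 log units; beyond the scatter) show that the tetramethylpiperidinyloxy group, attached at the carbonyl carbon, sits at lower numbers than the open chains attached there in compound 1 and compound 2. Reversing that, compound 4 is therefore expected to move back towards higher numbers, by roughly a 5.0-fold higher number from compound 3 to compound 4 (0.70 log units; beyond the scatter). Compound 4 is estimated at 3000 nM in this assay, within a range of 1200 nM to 8000 nM.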

Compound 4, half-maximal inhibitory concentration: 2100 nM
Beside the measured number, compound 4's estimate is 1.4-fold (0.15 log units) above it, and the stated range covers the measured number.
By their numbers in this assay, from the lowest: compound 3; then compounds 4 and 2 (each within the scatter of the next); then compound 1.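

In this assay, the open (2-(methanesulfonamido)ethyl)amino chain on the carbonyl carbon does not match the ring-bearing (2,2,6,6-tetramethylpiperidin-4-yl)oxy group (a 3.5-fold higher number from compound 3 to compound 4 (0.54 log units; beyond the scatter)). Among the open chains, methanesulfonamido and (methoxycarbonyl)methyl cannot be told apart (a 1.2-fold lower number from compound 2 to compound 4 (0.08 log units; within the scatter)), while methylsulfonyl in place of tert-butoxycarbonyl on the amine nitrogen gives a modest gain (a 2.6-fold lower number from compound 1 to compound 4 (0.42 log units; beyond the scatter)). No evidence here explains these steps.

On these data alone, whether the ring or the ester oxygen matters more stays open: compound 3 differs from compound 4 in both. The matching 2,2,6,6-tetramethylpiperidin-4-yl amide would separate the two.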